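The source may hold more compounds than are shown below. What is called first, only, known or untested is meant among the compounds shown, and "the series" means these compounds.

Three compounds share one core and differ in the acyl group of the amide and in the amine attached to the core. Compound 1 `COc1ccc(Nc2nc(Oc3cccc(NC(=O)/C=C/C(C)C)c3)c3sccc3n2)cn1` carries an amine unlike the other two; in a functional assay on A-431 cells (Homo sapiens) for inhibition, read by MTT assay, with a stated time of 72 h (on this read-out higher numbers stand for weaker inhibition and lower numbers for stronger inhibition), compound 1 gives only a limit, > 50000 nM. Compound 2 `CC(C)=CC(=O)Nc1cccc(Oc2nc(Nc3cccc(C#N)c3)nc3ccsc23)c1` gives 28300 nM in this assay, and compound 3 `CC/C=C/C(=O)Nc1cccc(Oc2nc(Nc3cccc(C#N)c3)nc3ccsc23)c1` gives 36200 nM in this assay. Among the numbers shown compound 3 sits alongside compound 2, since a 1.3-fold higher number from compound 2 to compound 3 (0.11 log units; within the scatter) lies within the scatter. Compound 4 `CC(C)/C=C/C(=O)Nc1cccc(Oc2nc(Nc3cccc(C#N)c3)nc3ccsc23)c1` has not yet been measured; it differs from compound 3 by methyl in place of hydrogen on a saturated chain carbon bound to a double-bonded chain carbon and a saturated chain carbon. Within the data shown here, the only measured step that bears on the acyl chain is the exchange of the alkenyl group, a 1.3-fold higher number from compound 2 to compound 3 (0.11 log units; within the scatter), which was small. The one limit, (the limit of > 50000 nM in this assay, at which 1 of the 3 values shown sits), concerns a compound with a different amine and says nothing about the acyl chain. A further small change in the same chain is therefore expected to move the number little: a 1.0-fold higher number from compound 3 to compound 4 (0.02 log units; within the scatter). Compound 4 is accordingly estimated at 38000 nM, with a range from 18000 nM to 80000 nM.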

Compound 4, half-maximal inhibitory concentration: 24100 nM
Estimate against measurement, compound 4: 1.6-fold (0.20 log units) above; the measured number falls inside the stated range.
By their numbers in this assay, from the lowest: compounds 4, 2 and 3 (each within the scatter of the next). At a limit, above all of these: compound 1.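

In this assay, methyl in place of hydrogen on a saturated chain carbon bound to a double-bonded chain carbon and a saturated chain carbon gives a 1.5-fold lower number from compound 3 to compound 4 (0.18 log units; within the scatter), and 3-methylbut-1-en-1-yl in place of 2-methylprop-1-en-1-yl on a carbonyl carbon gives a 1.2-fold lower number from compound 2 to compound 4 (0.07 log units; within the scatter), so all three acyl chains on the 3-cyanophenyl amine now read alike. Among these compounds, the first step beyond the scatter lies at the amine rather than the acyl chain, with 3-cyanophenyl in place of 6-methoxypyridin-3-yl on a nitrogen on an aromatic ring giving an at least 2.0-fold lower number from compound 1 to compound 4 (0.31 log units; beyond the scatter). That step starts from a limit and not from a number: the limit of > 50000 nM in this assay, at which 1 of the 4 values shown sits.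

As far as these compounds go, the true size of the amine step therefore remains open. Also open, from the compounds shown here alone, is whether a longer chain, a saturated acyl chain or a chain ending in an amine would read differently from these three.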